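The compounds below may be only part of what the source reports. "The series", "measured", "known", "first", "only" and "open" are said of these compounds alone.

Compound 1 `Cc1nn(C)c(Oc2cccc(F)c2)c1/C=N\CCCCCOc1cc2oc(=O)cc(C)c2cc1Cl` gives 9870 nM in a functional assay on U-87MG ATCC cells for antiproliferative activity against U-87 MG (Homo sapiens), read by MTT assay, with a stated time of 72 h; on this read-out higher numbers stand for weaker inhibition and lower numbers for stronger inhibition. Compound 2 `Cc1nn(C)c(Oc2ccc(I)cc2)c1/C=N\CCCCCOc1cc2oc(=O)cc(C)c2cc1Cl` gives > 25000 nM in this assay, which is a limit of the assay and not a number.

So compound 2 stands at the top of the numbers shown, weaker than compound 1 by the step of an at least 2.5-fold higher number from compound 1 to compound 2 (0.40 log units; beyond the scatter). Compound 3 `Cc1ccc(Oc2c(/C=N\CCCCCOc3cc4oc(=O)cc(C)c4cc3Cl)c(C)nn2C)cc1` differs from compound 2 by methyl in place of iodo on an aromatic carbon of a six-membered aromatic ring of carbon only, para to a large group. For the measured compounds named here, the one measured step, an at least 2.5-fold higher number from compound 1 to compound 2 (0.40 log units; beyond the scatter), changes the same phenyl ring but with a different group at a different place, so it bears only loosely on this change. Because compound 2 sits at the limit of > 25000 nM in this assay, at which 1 of the 2 values shown sits, the starting point itself is uncertain. A modest improvement is expected, an at least 1.2-fold lower number from compound 2 to compound 3 (0.09 log units; that floor lies within the scatter), in this assay. Compound 3 is therefore estimated at 20000 nM, with a range from 7000 nM to 50000 nM.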

Compound 3, half-maximal inhibitory concentration: 7970 nM
The estimate for compound 3 lay 2.5-fold (0.40 log units) above the measured number; low and high end bracket the measured number.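

Replacing 4-iodophenyl with 4-methylphenyl changes a single heavy atom at the same place on the ring and gives an at least 3.1-fold lower number from compound 2 to compound 3 (0.49 log units; beyond the scatter) in this assay, so the group at this place matters and a substituent there does not by itself cost activity. The true size of that step cannot be read, only its lower bound, because the starting value is not a number: the limit of > 25000 nM in this assay, at which 1 of the 3 values shown sits. Changing 3-fluorophenyl to 4-methylphenyl gives a 1.2-fold lower number from compound 1 to compound 3 (0.09 log units; within the scatter), so these two groups cannot be told apart on this read-out.

With only iodo and methyl at this place, no trend across groups can be drawn. As far as these compounds go, whether a methoxy, a chloro or an amine there would give a lower number than methyl remains open.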